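The source may hold more compounds than are shown below. What is called first, only, known or untested is meant among the compounds shown, and "the series" means these compounds.

Measured compounds in a functional assay on HepG2 cells (Homo sapiens) for inhibition, read by MTT assay, with a stated time of 72 h; on this read-out lower numbers stand for stronger inhibition and higher numbers for weaker inhibition:
- compound 1 `Cc1ccc(C(=O)OC2(C(=O)Nc3ccc([N+](=O)[O-])cc3)CCCCC2)cc1`: 61.2 nM
- compound 2 `O=C(OC1(C(=O)Nc2ccc([N+](=O)[O-])cc2)CCCCC1)c1ccc(Br)cc1`: 284 nM
- compound 3 `O=C(OC1(C(=O)Nc2ccc([N+](=O)[O-])cc2)CCCCC1)c1ccc([N+](=O)[O-])cc1`: 14.1 nM

Compound 3 gives the lowest number of the three, with compound 1 nearest and compound 2 furthest, so it is the strongest inhibitor in this set. Compound 4 `O=C(/C=C/c1ccccc1)OC1(C(=O)Nc2ccc([N+](=O)[O-])cc2)CCCCC1` differs from compound 3 by 2-phenylethenyl in place of 4-nitrophenyl on a carbonyl carbon. Within the data shown here, no measured step bears directly on this exchange; the known steps alter a substituent on an aromatic carbon, and they were modest to large: a 4.3-fold lower number from compound 1 to compound 3 (0.64 log units; beyond the scatter), a 20-fold lower number from compound 2 to compound 3 (1.30 log units; beyond the scatter) and a 4.6-fold higher number from compound 1 to compound 2 (0.67 log units; beyond the scatter). Those steps show that the group at this end of the ester shifts this assay well beyond the scatter, and compound 3 carries the group that gave the lowest number. Compound 4 is therefore expected to give a higher number than compound 3, a step of an 8.5-fold higher number from compound 3 to compound 4 (0.93 log units; beyond the scatter). The estimate for compound 4 is 120 nM, within a range of 30 nM to 500 nM.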

Compound 4, half-maximal inhibitory concentration: 52.9 nM
Compound 4: the middle estimate sits 2.3-fold (0.36 log units) above what was measured, within the range that was stated.
By their numbers in this assay, from the lowest: compound 3; then compounds 4 and 1 (each within the scatter of the next); then compound 2.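

Putting 2-phenylethenyl in place of the substituted phenyl on this carbonyl carbon keeps compound 4 level with the 4-methylphenyl ester in this assay, with a 1.2-fold lower number from compound 1 to compound 4 (0.06 log units; within the scatter) as the step. The same change gives a 3.8-fold higher number from compound 3 to compound 4 (0.57 log units; beyond the scatter) against 4-nitrophenyl and a 5.4-fold lower number from compound 2 to compound 4 (0.73 log units; beyond the scatter) against 4-bromophenyl, so compound 4 falls inside the span those aromatic esters set. Nothing available explains these shifts. Going by these compounds, whether an amine or a carboxylic acid on the aromatic ring, or a longer chain on this carbonyl carbon, would move the number stays open.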